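Aryl pyrazolyl enones: swapping the methoxyphenyl for difluorophenyl

The source may report more compounds than this note shows. Statements on the series, on what has been measured and on what is new or still open speak of the compounds shown alone.

Measured so far:
compound 1, `COc1ccc(C(=O)/C=C/c2cc(-c3cc(OC)c(OC)c(OC)c3)n[nH]2)cc1OC`, -93%
compound 2, `COc1ccc(C(=O)/C=C/c2cc(-c3cc(OC)c(OC)c(OC)c3)n[nH]2)cc1`, -48%

Going by the values given here, compound 2 gives the highest of the two numbers in a functional assay on UACC-62 cells (Homo sapiens) for cytotoxicity, read by sulforhodamine B assay, with a stated time of 48 h, tested at 100 uM; on this read-out higher numbers stand for a weaker effect at the one concentration tested and lower numbers for a stronger effect; its nearest neighbour is compound 1, and the single measured step, a number 45 percentage points higher from compound 1 to compound 2 (beyond the scatter), lies beyond the scatter. Compound 3, `COc1cc(-c2cc(/C=C/C(=O)c3ccc(F)c(F)c3)[nH]n2)cc(OC)c1OC`, has not yet been measured. It differs from compound 2 by 3,4-difluorophenyl in place of 4-methoxyphenyl on a carbonyl carbon.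

Among the compounds with values here, only one step is at hand, a number 45 percentage points higher from compound 1 to compound 2 (beyond the scatter), and it too takes a methoxy group out of the series, raising the number sharply. Within the data shown here, no measured pair speaks to fluorine, so the bearing of that step on the present change is indirect. The expectation for compound 3 is therefore a modest further rise, a number 18 percentage points higher from compound 2 to compound 3 (beyond the scatter), with wide uncertainty in both directions. Compound 3 is estimated at -30%, within a range from -70% to 10%.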

Compound 3, a percentage reported as activity, at one concentration (the size of the read-out at that concentration, not a potency): -81%
Beside the measured number, compound 3's estimate is 51 percentage points above it, and the stated range ends above it.
By their numbers in this assay, from the lowest: compound 1; then compound 3; then compound 2.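

In this assay the aryl group on the carbonyl carbon does not need a methoxy group for a strong effect at the one concentration tested: 3,4-difluorophenyl in place of 4-methoxyphenyl gives a number 33 percentage points lower from compound 2 to compound 3 (beyond the scatter) and so reverses much of the rise seen on removing a methoxy group. Set against 3,4-dimethoxyphenyl, the same difluorophenyl gives a number 12 percentage points higher from compound 1 to compound 3 (beyond the scatter), a smaller gap that leaves compound 1 with the lowest number of the three. Nothing measured here accounts for either step.

Three compounds cannot show whether the two substituents on this aryl group matter more than their identity, as compound 1 and compound 3 both stand below compound 2. A single fluorine, a chlorine, a nitrile or an amine at this place remains an open comparison.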